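Aryl amine variation on a cyclopropyl pyrimidine series

The compounds below may be only part of what the source reports. "The series", "measured", "known", "first", "only" and "open" are said of these compounds alone.

Within the data shown here, compound 1 (`O=C(NCCCNc1nc(Nc2cccnc2)ncc1C1CC1)C1CCC1`) sits second highest of the three numbers so far in an assay on isolated protein for inhibition of serine/threonine-protein kinase TBK1 (Homo sapiens) (a higher number here means a weaker inhibitor, a lower number a stronger inhibitor), giving 13 nM. Compound 3 (`Cc1nn(C)c2cc(Nc3ncc(C4CC4)c(NCCCNC(=O)C4CCC4)n3)ccc12`) gives 7 nM in this assay, a number within the scatter of compound 1. Compound 2 (`CC(=O)N1CCC(C(=O)NCCCNc2nc(Nc3cccc(F)c3)ncc2Br)CC1`) gives 430 nM in this assay, a gap beyond the scatter from compound 1; compound 2 differs from compound 1 in more than one place, so that gap cannot be tied to a single change.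

Compound 4 (`CN(C)Cc1ccc(Nc2ncc(C3CC3)c(NCCCNC(=O)C3CCC3)n2)cc1`) is not yet measured. It differs from compound 1 in one place: 4-((dimethylamino)methyl)phenyl in place of pyridin-3-yl on a nitrogen on an aromatic ring. Among the measured compounds shown here, no pair of measured compounds isolates this change. Compound 3 shows that another aryl group on the same nitrogen still gives a low number, at 7 nM, while the fluorophenyl of compound 2 arrives together with a second change and offers no clean guide. The step of a 1.2-fold higher number from compound 1 to compound 4 (0.06 log units; within the scatter) is therefore expected to be small, in no clear direction, and probably within the scatter. Compound 4 is estimated at 15 nM in this assay, with a range from 4 nM to 60 nM.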

Compound 4, half-maximal inhibitory concentration: 6 nM
Compound 4: the middle estimate sits 2.5-fold (0.40 log units) above what was measured; measured number inside the range.
By their numbers in this assay, from the lowest: compounds 4, 3 and 1 (each within the scatter of the next, the first and the last beyond it); then compound 2.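

Among these compounds, on the nitrogen on an aromatic ring, 4-((dimethylamino)methyl)phenyl in place of pyridin-3-yl gives a 2.2-fold lower number from compound 1 to compound 4 (0.34 log units; beyond the scatter) in this assay, a modest step and the only single-place change that can be read. This position therefore accepts a larger group with a carbon-only aromatic ring and a dimethylaminomethyl substituent without any rise in the number, and compound 4 lies within the scatter of compound 3, so two quite different aryl groups on this nitrogen give similar values. The step cannot be divided between the loss of the ring nitrogen of pyridin-3-yl and the gain of the dimethylaminomethyl group, and nothing available accounts for it.

Still open, as far as these compounds go, is whether a plain phenyl on the same nitrogen would give a number closer to that of compound 1 or to that of compound 4, which would show how much of the step belongs to the amine. Also open, from the compounds shown here alone, is whether a morpholine in place of the dimethylamino group, or a longer chain between the amine and the ring, would keep the number as low.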